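Cyclopropyl for Methyl on a Cytotoxicity-Silent Core

The source may hold more compounds than are shown below. What is called first, only, known or untested is meant among the compounds shown, and "the series" means these compounds.

Compound 2 `Cc1nn2ccc(Cl)cc2c1C(=O)NCc1ccc(N2CCC(c3ccc(OC(F)(F)F)cc3)CC2)cc1` was tested in an ADME assay on Vero cells (Chlorocebus sabaeus) for cytotoxicity, read by CCK-8 assay, with a stated time of 72 h; on this read-out lower numbers stand for stronger inhibition and higher numbers for weaker inhibition. In this assay compound 2 gives only a limit of the assay, > 100000 nM. Its nearest measured neighbour, compound 1 `Cc1ccc2c(C(=O)NCc3ccc(N4CCC(c5ccc(OC(F)(F)F)cc5)CC4)cc3)c(C)nn2c1`, shares the same fate. In this assay compound 1 likewise gives only a limit, > 100000 nM. For the measured compounds named here, the one measured step, a step that the two limits leave unreadable from compound 1 to compound 2, therefore tells nothing about size; all that is known is the limit of > 100000 nM in this assay, at which 2 of the 2 values shown sit, so no value sets compound 2 apart from compound 1 in this assay.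

Compound 3 `O=C(NCc1ccc(N2CCC(c3ccc(OC(F)(F)F)cc3)CC2)cc1)c1c(C2CC2)nn2ccc(Cl)cc12` differs from compound 2 by cyclopropyl in place of methyl on an aromatic carbon, the change sitting on an aromatic carbon of a five-membered aromatic ring with 2 nitrogen, part of a fused system of two rings. Going by the values given here, no measured step bears on this exchange, and both measured compounds sit at the same limit. Compound 3 is therefore expected to stay at or near that limit, a step that the limit leaves unreadable from compound 2 to compound 3 being expected. The estimate for compound 3 in this assay is 150000 nM, within 50000 nM to 600000 nM.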

Compound 3, half-maximal inhibitory concentration: > 100000 nM
Compound 3: no number, only a limit; the forecaster's own chance of this, stated with the estimate: 80%; the middle value does not contradict the limit.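

In this assay, for the compounds shown here, compound 3 also gives only a limit, so no step from compound 2 to compound 3 can be read, because neither compound has a number: the limit of > 100000 nM in this assay, at which 3 of the 3 values shown sit. The compounds shown leave open whether cyclopropyl and methyl differ at all in this assay.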